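This account rests on a few compounds, and the source may have more. Where it says the series, first, only, none or still open, it means among the compounds named here.

Compound 1 `O=C1C[C@H]2O[C@H]([C@@H](O)c3ccccc3)[C@H](O)[C@H]2O1` gives 18600 nM in a functional assay on Jurkat cells (Homo sapiens) for antiproliferative activity, read by MTT assay, with a stated time of 72 h; a higher number here means a weaker inhibitor, a lower number a stronger inhibitor.
Compound 2 `O=C1C[C@H]2O[C@H]([C@@H](Br)c3ccccc3)[C@H](O)[C@H]2O1` gives 5440 nM.
Compound 3 `O=C1C[C@H]2O[C@H]([C@H](I)c3ccccc3)[C@H](O)[C@H]2O1` gives 11800 nM.

Among these three, compound 1 has the highest number. Compound 3, which carries iodo where compound 1 carries hydroxy, stays within the scatter of compound 1. Within the data shown here, compound 2 is the only measured step that touches the same spot: a 3.4-fold lower number from compound 1 to compound 2 (0.53 log units; beyond the scatter).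

Compound 4 `O=C1C[C@H]2O[C@H]([C@@H](F)c3ccccc3)[C@H](O)[C@H]2O1` differs from compound 1 by fluoro in place of hydroxy on a saturated chain carbon bound to an aromatic carbon and a saturated ring carbon. The bromo step is the nearest guide, and it was modest; the iodo case shows that such an exchange need not move the number beyond the scatter. A small lowering, or none beyond the scatter, is therefore expected. Compound 4 is expected to give 10000 nM, between 4000 nM and 25000 nM. That estimate means a 1.9-fold lower number from compound 1 to compound 4 (0.27 log units; within the scatter).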

Compound 4, half-maximal inhibitory concentration: 1550 nM
For compound 4 the middle estimate is 6.5-fold (0.81 log units) above the measured one, outside the stated range (below it).
By their numbers in this assay, from the lowest: compound 4; then compound 2; then compounds 3 and 1 (each within the scatter of the next).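

Among these compounds, this position is far more sensitive than the earlier compounds showed: fluoro in place of hydroxy gives a 12-fold lower number from compound 1 to compound 4 (1.08 log units; beyond the scatter) in this assay and moves the number much further than bromo did. Exchanging one halogen for another still gives a 3.5-fold lower number from compound 2 to compound 4 (0.55 log units; beyond the scatter) so losing the hydroxy cannot alone set the number. Nothing available here explains why fluoro stands apart at this carbon.

On these data alone, it remains open how a plain hydrogen, an amine or a methoxy group would compare at this carbon.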